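From 4-(tert-butyl)phenyl to naphthalen-2-yl on the shared core

The source may report more compounds than this note shows. Statements on the series, on what has been measured and on what is new or still open speak of the compounds shown alone.

Values measured so far in a functional assay on SK-N-SH cells (Homo sapiens) for cytotoxicity, read by MTT assay, with a stated time of 48 h; a higher number here means a weaker inhibitor, a lower number a stronger inhibitor
compound 1 `C=C(c1ccc(OC)cc1)c1cc(OC)c(OC)c(OC)c1-c1ccc(OC)cc1` gives 75000 nM
compound 2 `C=C(c1ccc(OC)cc1)c1cc(OC)c(OC)c(OC)c1-c1ccccc1` gives 31000 nM
compound 3 `C=C(c1ccc(OC)cc1)c1cc(OC)c(OC)c(OC)c1-c1ccc(C(C)(C)C)cc1` gives 24000 nM

Compound 3 sits together with compound 2 at the lower end of these numbers, and the two cannot be told apart: the result is a 1.3-fold lower number from compound 2 to compound 3 (0.11 log units; within the scatter) in this small set. Compound 1 stands clearly apart from compound 3 with a 3.1-fold lower number from compound 1 to compound 3 (0.49 log units; beyond the scatter) as the measured gap.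

The next molecule is compound 4 (`C=C(c1ccc(OC)cc1)c1cc(OC)c(OC)c(OC)c1-c1ccc2ccccc2c1`), which carries naphthalen-2-yl in place of 4-(tert-butyl)phenyl on an aromatic carbon. Within the data shown here, no compound measured so far carries this group, so the estimate rests on related changes at the same place. Replacing the methoxy of compound 1 with hydrogen gave a 2.4-fold lower number from compound 1 to compound 2 (0.38 log units; beyond the scatter) as a modest step. Compound 2 and compound 3 both lack that methoxy, as does compound 4, and the step of a 1.3-fold lower number from compound 2 to compound 3 (0.11 log units; within the scatter) between those two stayed small. No step beyond the scatter is therefore expected in this assay for this change.

The estimated step is a 1.0-fold higher number from compound 3 to compound 4 (0.02 log units; within the scatter) and would leave the two compounds level. For compound 4 the expected value is 25000 nM with an estimated range from 10000 nM to 60000 nM in this measurement.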

Compound 4, half-maximal inhibitory concentration: 6000 nM
Compound 4: the middle estimate sits 4.2-fold (0.62 log units) above what was measured; the whole stated range lies above it.
By their numbers in this assay, from the lowest: compound 4; then compounds 3 and 2 (each within the scatter of the next); then compound 1.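

In this assay, among these compounds, this position proved more sensitive to the choice of aromatic group than the earlier compounds suggested: naphthalen-2-yl gives a 4.0-fold lower number from compound 3 to compound 4 (0.60 log units; beyond the scatter) and also a 5.2-fold lower number from compound 2 to compound 4 (0.71 log units; beyond the scatter) even though the phenyl and 4-(tert-butyl)phenyl compounds could not be told apart. Since 4-(tert-butyl)phenyl and naphthalen-2-yl each have 10 heavy atoms, all carbon, and no hydrogen-bond donors or acceptors, the count of heavy atoms does not separate them; what differs in that count is one six-membered aromatic ring against two, and the widest gap in the set is a 13-fold lower number from compound 1 to compound 4 (1.10 log units; beyond the scatter) as a large step. Nothing here explains why this exchange lowers the number, as no supporting measurement bears on the result.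

The compounds shown leave open whether the second aromatic ring is what matters, as only this one two-ring group appears at this position. They also leave open how an amine, a carboxylic acid or a fluorine on the aromatic group here would behave, and whether the lower number of compound 4 would carry over to any other cell type.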